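Bromophenoxy analogue: a methoxy pattern change at the assay limit

This account rests on a few compounds, and the source may have more. Where it says the series, first, only, none or still open, it means among the compounds named here.

Of the compounds shown here, two have been measured in a functional assay on 4T1 cells (Mus musculus) for cytotoxicity, read by MTT assay, with a stated time of 48 h; on this read-out higher numbers stand for weaker inhibition and lower numbers for stronger inhibition: compound 1 (`COc1cc(OC)c(/C=C/C(=O)/C=C/c2cc3ccccc3nc2Oc2ccccc2)c(OC)c1`) and compound 2 (`COc1ccc(OC)c(/C=C/C(=O)/C=C/c2cc3ccccc3nc2Oc2ccc(Br)cc2)c1`). Compound 1 gives > 10000 nM as a limit of the assay, not a number. Compound 2 gives > 10000 nM as a limit too, so it has no numeric position and stands at the limit of > 10000 nM in this assay, at which 2 of the 2 values shown sit, in this small set. Compound 3 (`COc1cc(OC)c(/C=C/C(=O)/C=C/c2cc3ccccc3nc2Oc2ccc(Br)cc2)c(OC)c1`) is still unmeasured. It differs from compound 2 by 2,4,6-trimethoxyphenyl in place of 2,5-dimethoxyphenyl on a double-bonded chain carbon bound to a double-bonded chain carbon. Compound 1 carries the same 2,4,6-trimethoxyphenyl and shows no measurable value. The step expected in this assay is small, estimated as a step that the limit leaves unreadable from compound 2 to compound 3 with no firm direction. Compound 3 is expected at 12000 nM with an estimated range from 4000 nM to 40000 nM and may well read as a limit again.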

Compound 3, half-maximal inhibitory concentration: > 10000 nM
Compound 3: no number, only a limit; the forecaster's own chance of this, stated with the estimate: 70%; the middle value is on the limit's open side.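

Compound 3 gives > 10000 nM in this assay, a limit of the assay and not a number. No step among compound 1, compound 2 and compound 3 can be read, and all three sit at one limit: the limit of > 10000 nM in this assay, at which 3 of the 3 values shown sit.

The compounds shown leave open whether exchanging 2,5-dimethoxyphenyl for 2,4,6-trimethoxyphenyl, or hydrogen for bromo, changes cytotoxicity at all.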